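Hydroxymethyl chain for methylsulfonyl chain: expected tolerability

The source may hold more compounds than are shown below. What is called first, only, known or untested is meant among the compounds shown, and "the series" means these compounds.

Two members of the series have been run in an ADME assay on HEp-2 cells (Homo sapiens) for cytotoxicity, with a stated time of 4 days; a lower number here means that less compound is tolerated, a higher number that more compound is tolerated. Compound 1 `CS(=O)(=O)CCCn1c(Cn2cc(S(C)(=O)=O)c3ccncc32)nc2cc(Cl)ccc21` gives > 100000 nM in this assay, which is a limit of the assay rather than a number. Compound 2 `CS(=O)(=O)CCCn1c(Cn2nc(S(C)(=O)=O)c3ccncc32)nc2cc(Cl)ccc21` gives > 100000 nM in this assay, again a limit and not a number. For the measured compounds named here, both values sit at the same limit (the limit of > 100000 nM in this assay, at which 2 of the 2 values shown sit), so no order between compound 1 and compound 2 can be read, and no measured step in this assay exists.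

Compound 3 `CC(C)(CO)Cn1c(Cn2nc(S(C)(=O)=O)c3ccncc32)nc2cc(Cl)ccc21` has not been measured. It differs from compound 2 in a single place: 1-(hydroxymethyl)-1-methylethyl in place of 2-(methylsulfonyl)ethyl on a saturated chain carbon bound to an aromatic nitrogen. The rest of the molecule is unchanged.

The expected step in this assay, a number no higher from compound 2 to compound 3 (the limit leaves the size open), is none beyond the scatter, given that both tested compounds sit at the limit of > 100000 nM in this assay, at which 2 of the 2 values shown sit, and nothing in the series points elsewhere. Compound 3 is accordingly estimated at 100000 nM in this assay, with a range from 30000 nM to 300000 nM, and it is quite possible that the assay will again report only a limit.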

Compound 3, half-maximal cytotoxic concentration: > 100000 nM
Compound 3 gave a limit, no number; the forecaster's own chance of this, stated with the estimate: 70%; the middle value sits exactly at the limit.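

No step can be read from compound 2 to compound 3 in this assay, because both results are limits and not numbers: the limit of > 100000 nM in this assay, at which 3 of the 3 values shown sit.

The compounds shown leave open how compound 1, compound 2 and compound 3 would rank once numbers replace limits, and whether any change in the series would give a readable value.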